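The compounds below may be only part of what the source reports. "The series", "measured", "known", "first", "only" and "open" are said of these compounds alone.

Measured in a functional assay (blood) for inhibition, with Homo sapiens as the target; on this read-out higher numbers stand for weaker inhibition and lower numbers for stronger inhibition:
- Compound 1 `OC1O[C@H](CO/N=C2\CCc3cc(Sc4cc(F)cc(C5CCOCC5)c4)ccc32)[C@H](O)[C@H](O)[C@H]1O`: > 2500 nM (a limit of the assay)
- Compound 2 `CC(=O)O/N=C(\C)c1ccc(Sc2cc(F)cc(C3CCOCC3)c2)cc1`: 50 nM

Compound 1 has no number here, only a limit: the limit of > 2500 nM in this assay, at which 1 of the 2 values shown sits. Compound 3 `Fc1cc(Sc2ccc3c(c2)CC/C3=N\OCc2ccncc2)cc(C2CCOCC2)c1` keeps the core of compound 1 and carries one change, (pyridin-4-yl in place of 3,4,5,6-tetrahydroxyoxan-2-yl on a saturated chain carbon bound to an oxygen on an unsaturated carbon). Going by the values given here, no measured step covers this change. The expectation leans on compound 2, at 50 nM, which also lacks the 3,4,5,6-tetrahydroxyoxan-2-yl group. A large step towards stronger inhibition, meaning a lower number in this assay, is therefore expected. The expected size is an at least 16-fold lower number from compound 1 to compound 3 (1.22 log units; beyond the scatter). For compound 3 the estimated value is 150 nM, with an expected range of 30 nM to 800 nM.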

Compound 3, half-maximal inhibitory concentration in the Homo sapiens assay: 90 nM
Compound 3: the middle estimate sits 1.7-fold (0.22 log units) above what was measured; measured number inside the range.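

In the Homo sapiens assay, putting pyridin-4-yl in place of 3,4,5,6-tetrahydroxyoxan-2-yl on the shared core gives an at least 27-fold lower number from compound 1 to compound 3 (1.44 log units; beyond the scatter), with compound 3 at 90 nM. In the Homo sapiens assay compound 1 gives > 2500 nM, which is a limit of the assay. This size is only a bound, because compound 1 stands at a limit of the assay: the limit of > 2500 nM in the Homo sapiens assay, at which 1 of the 3 values shown sits.

In a physicochemical assay for solubility (a lower number here means a less soluble compound, a higher number a more soluble compound), compound 1 gives 81000 nM and compound 3 gives 100000 nM. In the physicochemical assay the same change gives a 1.2-fold higher number from compound 1 to compound 3 (0.09 log units; within the scatter), so this read-out does not separate the two compounds. The compounds shown leave open whether the aromatic ring or its nitrogen matters at this place. They also leave open how a phenyl, an amine or a carboxylic acid on the same saturated chain carbon would compare with pyridin-4-yl.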